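Removing a Methoxy Group from Two Quinoline Cores

This account rests on a few compounds, and the source may have more. Where it says the series, first, only, none or still open, it means among the compounds named here.

The study compares four compounds in a functional assay on HL-60 cells (Homo sapiens) for antiproliferative activity; a lower number here means a stronger inhibitor, a higher number a weaker inhibitor. Compound 1 `Oc1cccc2nccc(O)c12` carries two hydroxy groups on its core. In this assay compound 1 reaches only a limit, reported as > 30000 nM. Compound 2 `COc1ccc(O)c2c(O)ccnc12` adds a methoxy group to that core, and in this assay compound 2 gives 17700 nM. The step of an at least 1.6-fold higher number from compound 2 to compound 1 (0.22 log units; that floor lies within the scatter) corresponds to hydrogen in place of methoxy on an aromatic carbon. Compound 3 `COc1cc2c(c(OC)c1OC)c(=O)ccn2C` rests on a different core; how the two cores differ is not broken down here. In this assay compound 3 also reaches only a limit, reported as > 30000 nM. Two of the three measured values therefore sit at the limit of > 30000 nM in this assay, at which 2 of the 3 values shown sit.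

Compound 4 `COc1cc(OC)c2c(=O)ccn(C)c2c1` is not yet measured. It differs from compound 3 by hydrogen in place of methoxy on an aromatic carbon, the same kind of change as that from compound 2 to compound 1, although the surroundings differ: in compound 2 the carbon is ortho to a fused ring, meta to a fused ring and para to a hydroxy group, whereas in compound 3 it is ortho to two methoxy groups, meta to a fused ring and para to a fused ring. The earlier step made the number higher, so compound 4 is expected to move by a step that the limit leaves unreadable from compound 3 to compound 4, most likely ending again at a limit. For compound 4 the estimate is 45000 nM, with a range from 15000 nM to 120000 nM.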

Compound 4, half-maximal inhibitory concentration: > 30000 nM
Compound 4: only a limit was reported; the forecaster's own chance of this, stated with the estimate: 70%; the middle value is on the limit's open side.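

In this assay compound 4 gives only a limit, > 30000 nM. Compound 3 also gives only a limit, so no step can be read between compound 3 and compound 4. Most values now rest at the same limit: the limit of > 30000 nM in this assay, at which 3 of the 4 values shown sit.

The compounds shown leave open whether hydrogen in place of methoxy changes activity at all on the core of compound 3.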